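Swapping the trifluoromethyl-pyridyl arm for a fluorophenyl arm

The compounds below may be only part of what the source reports. "The series", "measured", "known", "first", "only" and "open" are said of these compounds alone.

Three compounds sharing one core differ only in the group carried on the amine nitrogen of the piperazine-like ring. Compound 1 `N#Cc1cccc(COc2ccc(-c3cc(CN4CCN(Cc5ccc(C(F)(F)F)cc5)CC4)no3)cc2)c1` carries a 4-(trifluoromethyl)benzyl group and in a functional assay on Mahlavu cells (Homo sapiens) for antiproliferative activity, read by sulforhodamine B assay, with a stated time of 72 h (on this read-out lower numbers stand for stronger inhibition and higher numbers for weaker inhibition), compound 1 gives 10600 nM. Compound 2 `N#Cc1cccc(COc2ccc(-c3cc(CN4CCN(c5ccc(C(F)(F)F)cc5)CC4)no3)cc2)c1` carries a 4-(trifluoromethyl)phenyl group and gives 2700 nM. Compound 3 `N#Cc1cccc(COc2ccc(-c3cc(CN4CCN(c5ccc(C(F)(F)F)cn5)CC4)no3)cc2)c1` carries a 5-(trifluoromethyl)pyridin-2-yl group and gives 1300 nM, the lowest of the three numbers; its nearest neighbour is compound 2, and the step of a 2.1-fold lower number from compound 2 to compound 3 (0.32 log units; beyond the scatter) sets them apart, while an 8.2-fold lower number from compound 1 to compound 3 (0.91 log units; beyond the scatter) separates it from compound 1.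

Compound 4 `N#Cc1cccc(COc2ccc(-c3cc(CN4CCN(c5ccc(F)cc5)CC4)no3)cc2)c1` is not yet measured. The change from compound 3 is 4-fluorophenyl in place of 5-(trifluoromethyl)pyridin-2-yl on an amine nitrogen in a ring. Going by the values given here, two pieces of this change are informed by the measured steps: the ring nitrogen is removed, which runs opposite to the step of a 2.1-fold lower number from compound 2 to compound 3 (0.32 log units; beyond the scatter), and the trifluoromethyl becomes a single fluorine, for which no measured step exists. The step of a 3.9-fold lower number from compound 1 to compound 2 (0.59 log units; beyond the scatter) does not bear directly here, since both compounds keep an aromatic ring attached straight to the nitrogen. A modest rise in the number is therefore expected for compound 4, estimated as a 2.3-fold higher number from compound 3 to compound 4 (0.36 log units; beyond the scatter). The value expected for compound 4 is 3000 nM, in a range from 1000 nM to 9000 nM.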

Compound 4, half-maximal inhibitory concentration: 2200 nM
For compound 4 the middle estimate is 1.4-fold (0.13 log units) above the measured one, within the range that was stated.
By their numbers in this assay, from the lowest: compounds 3, 4 and 2 (each within the scatter of the next, the first and the last beyond it); then compound 1.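

In this assay, replacing the trifluoromethyl on the aromatic ring with a single fluorine, a step of a 1.2-fold lower number from compound 2 to compound 4 (0.09 log units; within the scatter), has no readable effect at this position. The 4-fluorophenyl arm, with 7 heavy atoms, also cannot be told apart from the 10-atom 5-(trifluoromethyl)pyridin-2-yl arm, given a 1.7-fold higher number from compound 3 to compound 4 (0.23 log units; within the scatter), so neither the trifluoromethyl nor the ring nitrogen is needed to keep the number at this level. The 4-(trifluoromethyl)benzyl arm still stands apart, with a 4.8-fold lower number from compound 1 to compound 4 (0.68 log units; beyond the scatter), and the new result shows that this gap holds with a different aromatic arm.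

No measured evidence explains how these arms produce their numbers. Going by these compounds, whether the ring needs a substituent at all remains open, as do a plain phenyl ring and a chlorine or methoxy group in place of the fluorine.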